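Compound 3: an aryl swap on a barely active series

The source may hold more compounds than are shown below. What is called first, only, known or untested is meant among the compounds shown, and "the series" means these compounds.

Measured in a functional assay on A549 cells (Homo sapiens) for antiproliferative activity, read by MTT assay; a lower number here means a stronger inhibitor, a higher number a weaker inhibitor:
compound 1 `Cc1ccc(-n2cc(COc3ccc(/C=C/C(=O)c4cc5c(cc4O)OC(C)(C)CC5)cc3)nn2)cc1Br`: 125000 nM
compound 2 `CC1(C)CCc2c(ccc(C(=O)/C=C/c3ccc(OCc4cn(-c5ccc(Cl)cc5)nn4)cc3)c2O)O1`: "not active" (no number reported)

Compound 2 has no number to start from: in this assay compound 2 is reported as "not active" (no number reported). Compound 3 `COc1ccc(-n2cc(COc3ccc(/C=C/C(=O)c4ccc5c(c4O)CCC(C)(C)O5)cc3)nn2)c([N+](=O)[O-])c1` differs from it by one change, (4-methoxy-2-nitrophenyl in place of 4-chlorophenyl on an aromatic nitrogen), with 4-methoxy-2-nitrophenyl in place of 4-chlorophenyl on an aromatic nitrogen. Going by the values given here, no measured step shows what such a swap does. Among the compounds with values here, a large step in this assay is not expected in either direction, and the only numeric anchor is compound 1 at 125000 nM. Compound 3 is expected at 100000 nM, with an estimated range of 30000 nM to 300000 nM.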

Compound 3, half-maximal inhibitory concentration: "not active" (no number reported)
For compound 3 the study gives words and no number; the estimate stays without a comparison.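

In this assay compound 2 and compound 3 are both reported as not active, without a number, so no step can be read between them. The compounds shown leave open what 4-methoxy-2-nitrophenyl in place of 4-chlorophenyl does to potency. No evidence bears on this result.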